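Bromo for Carboxy on a Second Core

The compounds below may be only part of what the source reports. "The series", "measured", "known", "first", "only" and "open" are said of these compounds alone.

Measured compounds:
Compound 1 `O=C(O)c1ccc(C(=O)/C(=C\c2ccc(O)c([N+](=O)[O-])c2)SCc2ccc(Br)cc2)cc1` — 50000 nM
Compound 2 `O=C(/C(=C\c1ccc(O)c([N+](=O)[O-])c1)SCc1ccc(Br)cc1)c1ccc(Br)cc1` — 10000 nM
Compound 3 `O=C(O)c1cc(/C=C(/Sc2ccc(Br)cc2)C(=O)c2c(F)c(F)c(F)c(F)c2F)ccc1O` — 25000 nM

In a functional assay on DU-145 cells (Homo sapiens) for inhibition, read by trypan blue exclusion, with a stated time of 96 h (a lower number here means a stronger inhibitor of growth, a higher number a weaker inhibitor of growth), compound 1 gives 50000 nM, and compound 2 gives 10000 nM. The change between them, (bromo in place of carboxy on an aromatic carbon), produced a 5.0-fold lower number from compound 1 to compound 2 (0.70 log units; beyond the scatter). Compound 3 gives 25000 nM in this assay; the difference between its core and the core of compound 1 is not broken down here, and compound 3 stands within the scatter of compound 1.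

Compound 4 `O=C(/C(=C\c1ccc(O)c(Br)c1)Sc1ccc(Br)cc1)c1c(F)c(F)c(F)c(F)c1F` has not been measured. It differs from compound 3 by bromo in place of carboxy on an aromatic carbon. This is the same kind of change as that from compound 1 to compound 2, but not the same: in the earlier pair the place was para to a large group, whereas here it is ortho to a hydroxy group (1 heavy atom) and meta to a large group.

Because the earlier change gave a 5.0-fold lower number from compound 1 to compound 2 (0.70 log units; beyond the scatter), a step in the same direction is expected for compound 4, though the different surroundings of the place make its size uncertain. The estimated step is a 3.1-fold lower number from compound 3 to compound 4 (0.49 log units; beyond the scatter). Compound 4 is therefore expected to give about 8000 nM in this assay, with a likely range from 3000 nM to 25000 nM.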

Compound 4, concentration for 50% growth inhibition: 1000 nM
For compound 4 the middle estimate is 8.0-fold (0.90 log units) above the measured one; measured number below the stated range.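

In this assay, bromo in place of carboxy lowers the number on the second core as it did on the first, and here the step is large, with a 25-fold lower number from compound 3 to compound 4 (1.40 log units; beyond the scatter). The direction of the change therefore carries over between these two cores, but its size does not, as the two steps set side by side show: the same change on two cores in this assay, a 5.0-fold lower number (0.70 log units; beyond the scatter) from compound 1 to compound 2 and a 25-fold lower number (1.40 log units; beyond the scatter) from compound 3 to compound 4, 5.0-fold (0.70 log units) apart, beyond the scatter of two such steps. This does not show what sets the size, as the cores of compound 1 and compound 3 differ in more than one place and the change itself sits in different surroundings, so two pairs cannot separate the effect of the place, here ortho to a hydroxy group, from that of the rest of the core, and they give no rule for the size of the step on any further core.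

The compounds shown leave open whether another group at this place, such as chloro, methyl or an amine, would give a step like that of bromo. They also leave open whether a longer chain on the sulfur, or a methoxy group in place of the hydroxy group, would alter the size of the step on either core.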